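Removing a Methyl Near the Hydroxyl: Expected Effect

This account rests on a few compounds, and the source may have more. Where it says the series, first, only, none or still open, it means among the compounds named here.

Compound 1 `O=C(CN(c1nc(Cl)nc2[nH]cnc12)C1CC1)N[C@@H](CO)C(=O)OCc1ccccc1` and compound 2 `C[C@@H](O)[C@H](NC(=O)CN(c1nc(Cl)nc2[nH]cnc12)C1CC1)C(=O)OCc1ccccc1` share one core; compound 3 `C[C@@H](O)[C@H](NC(=O)CN(c1ncnc2c1ncn2C1CCCCO1)C1CC1)C(=O)OCc1ccccc1` and compound 4 `O=C(CN(c1ncnc2c1ncn2C1CCCCO1)C1CC1)N[C@@H](CO)C(=O)OCc1ccccc1` share another, and the difference between the two cores is not broken down here. In a functional assay on the whole organism (Tail, strain ICR) with Mus musculus as the target, in the tail flick test, with a stated time of 60 min, at a dose of 25 umol/kg by the oral route (a higher number here means a stronger effect of the compound at the dose given, a lower number a weaker effect), compound 1 gives 34.2%, compound 2 gives 29.7%, and compound 3 gives 28.4%. The change from compound 2 to compound 1 is hydrogen in place of methyl on a saturated chain carbon bound to an oxygen on a saturated carbon and a saturated chain carbon, and it produced a number 4.5 percentage points higher from compound 2 to compound 1 (within the scatter). The same change, (hydrogen in place of methyl on a saturated chain carbon bound to an oxygen on a saturated carbon and a saturated chain carbon), turns compound 3 into compound 4. Since the step from compound 2 to compound 1 stayed within the scatter, a step of about the same size is expected from compound 3 to compound 4, namely a number 3.6 percentage points higher from compound 3 to compound 4 (within the scatter). Compound 4 is therefore estimated to give 32% in this assay, between 22% and 42%.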

Compound 4, a percentage reported as activity, at one dose (the size of the read-out at that dose, not a potency): 46.7%
Compound 4: the middle estimate sits 14.7 percentage points below what was measured, outside the stated range (above it).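

Replacing 1-hydroxyethyl with hydroxymethyl in this assay gives a number 18.3 percentage points higher from compound 3 to compound 4 (beyond the scatter). Set beside the earlier step, this larger step cannot be told apart from it: the same change on two cores in this assay, a number 4.5 percentage points higher (within the scatter) from compound 2 to compound 1 and a number 18.3 percentage points higher (beyond the scatter) from compound 3 to compound 4, 13.8 percentage points apart, within the scatter of two such steps So the data do not show that the change behaves differently on the two cores, but with only one pair on each core, they do not prove that its effect carries over unchanged either.

The compounds shown leave open how a longer chain or a carboxylic acid in place of the hydroxymethyl group would behave on either core. They also leave open whether an amine there would fit the same picture.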